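The source may hold more compounds than are shown below. What is called first, only, known or untested is meant among the compounds shown, and "the series" means these compounds.

Measured compounds in an assay on CHO cells for displacement of a labelled ligand from prostaglandin D2 receptor 2 (Homo sapiens), read by scintillation counting; on this read-out lower numbers stand for stronger inhibition and higher numbers for weaker inhibition:
Compound 1 `CC(C)Cc1ccncc1C#Cc1cc(Cl)ccc1OCC(=O)O` gives 4.9 nM.
Compound 2 `O=C(O)COc1ccc(Cl)cc1C#Cc1ccccc1Cl` gives 28 nM.
Compound 3 `O=C(O)COc1ccc(Cl)cc1C#Cc1ccccc1` gives 108 nM.

Going by the values given here, compound 3 stands highest of the three numbers; its nearest neighbour is compound 2, and the step of a 3.9-fold higher number from compound 2 to compound 3 (0.59 log units; beyond the scatter) is the only single change that has been measured. Compound 4 `O=C(O)COc1ccc(Cl)cc1C#Cc1cccnc1` differs from compound 3 by pyridin-3-yl in place of phenyl on a triple-bonded carbon. Among the compounds with values here, no measured step covers an exchange of this kind, so the only guide is the general spread of the series: compound 1 carries a pyridine on the triple-bonded carbon together with other changes and gives a far lower number than compound 3, but that comparison is not a single step. A modest lowering is therefore expected, a 1.5-fold lower number from compound 3 to compound 4 (0.19 log units; within the scatter), with wide uncertainty. Compound 4 is estimated at 70 nM, likely between 20 nM and 250 nM.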

Compound 4, inhibition constant: 117 nM
The estimate for compound 4 lay 1.7-fold (0.22 log units) below the measured number; low and high end bracket the measured number.
By their numbers in this assay, from the lowest: compound 1; then compound 2; then compounds 3 and 4 (each within the scatter of the next).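

In this assay, pyridin-3-yl in place of phenyl on a triple-bonded carbon stays within the scatter (a 1.1-fold higher number from compound 3 to compound 4 (0.03 log units; within the scatter)), while pyridin-3-yl in place of 2-chlorophenyl costs a modest step (a 4.2-fold higher number from compound 2 to compound 4 (0.62 log units; beyond the scatter)). The large gap to compound 1 now reads as a single change, the loss of the isobutyl group (a 24-fold higher number from compound 1 to compound 4 (1.38 log units; beyond the scatter)). No measurement shown explains these steps.

On these data alone, whether a methyl or a cyclopropyl on that aromatic carbon would carry the same gain stays open. So does whether a chloro on the pyridin-3-yl ring would add to it.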